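This account rests on a few compounds, and the source may have more. Where it says the series, first, only, none or still open, it means among the compounds named here.

The measured compounds and their values:

Compound 1 `CCOC(=O)C1=Cc2ccccc2OC1(OCc1cc(-c2ccc(F)cc2F)no1)C(F)(F)F` in a functional assay on DU-145 cells (Homo sapiens) for inhibition, read by MTT assay, with a stated time of 24 h (a lower number here means a stronger inhibitor, a higher number a weaker inhibitor), gives > 150000 nM, which is a limit of the assay.
Compound 2 `CCOC(=O)C1=Cc2ccccc2OC1(OCc1cc(-c2ccc(C)cc2)no1)C(F)(F)F` in this assay gives > 150000 nM, again a limit.
Compound 3 `CCOC(=O)C1=Cc2ccccc2OC1(OCc1cc(-c2ccc(OC)cc2)no1)C(F)(F)F` in this assay gives > 150000 nM, also a limit.

Compound 3 thus stands at the same limit as the other two, and no number separates it from them. The three measured steps, a step that the two limits leave unreadable from compound 1 to compound 2, a step that the two limits leave unreadable from compound 1 to compound 3 and a step that the two limits leave unreadable from compound 2 to compound 3, are all unreadable for the same reason, namely (the limit of > 150000 nM in this assay, at which 3 of the 3 values shown sit). Compound 4 `CCOC(=O)C1=Cc2ccccc2OC1(OCc1cc(-c2ccc(Br)cc2)no1)C(F)(F)F` differs from compound 3 by bromo in place of methoxy on an aromatic carbon. For the measured compounds named here, the only steps that bear on this change are the three above, and all of them are hidden by the limit, so the bromo compound has no readable precedent in this assay. With every variation of the pendant phenyl ring so far sitting at the limit, compound 4 is expected to stay there too, the estimated step being a step that the limit leaves unreadable from compound 3 to compound 4. Compound 4 is therefore estimated at 250000 nM in this assay, within 100000 nM to 600000 nM.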

Compound 4, half-maximal inhibitory concentration: 71700 nM
Compound 4: the middle estimate sits 3.5-fold (0.54 log units) above what was measured; measured number outside the range, below it.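

For the compounds shown here, compound 4 holds the only number in this assay, which shows that a change on the pendant phenyl ring can move this series off its limit. Bromo in place of methoxy gives an at least 2.0-fold lower number from compound 3 to compound 4 (0.32 log units; beyond the scatter), bromo in place of methyl gives an at least 2.0-fold lower number from compound 2 to compound 4 (0.32 log units; beyond the scatter), and 4-bromophenyl in place of 2,4-difluorophenyl gives an at least 2.0-fold lower number from compound 1 to compound 4 (0.32 log units; beyond the scatter). These three steps give only a smallest size, and the steps among the other three compounds cannot be read: the limit of > 150000 nM in this assay, at which 3 of the 4 values shown sit.

Going by these compounds, it remains open whether chloro, iodo, a nitrile or an amine on that same aromatic carbon would also give a number in this assay. On these data alone, compound 4 gives 71700 nM, and how a carboxylic acid in place of the ethyl ester would shift that value is equally open.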